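The source may report more compounds than this note shows. Statements on the series, on what has been measured and on what is new or still open speak of the compounds shown alone.

Of the compounds shown here, three sharing one core have so far been tested in an assay on CHO cells for displacement of a labelled ligand from adenosine receptor A1 (Homo sapiens), read by scintillation counting, tested at 10 uM; a higher number here means more inhibition at the concentration tested (going by the name of the read-out), a lower number less inhibition. Compound 1 `Cc1c(Br)sc(N)c1C(=O)c1ccc(Cl)cc1` gives 1% in this assay. Compound 2 `CC(C)(C)Cc1c(-c2cccnc2)sc(N)c1C(=O)c1ccc(Cl)cc1` gives 1%. Compound 3 `CC(C)(C)Cc1c(Br)sc(N)c1C(=O)c1ccc(Cl)c(Cl)c1` gives 1%. At the digits shown, compound 2 stands level with compound 1 and with compound 3, and the differences among these three lie within the usual scatter of repeated measurements, so the inhibition in this assay is level for all three; all sit at a low reading.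

Compound 4 `CC(C)(C)Cc1c(-c2ccsc2)sc(N)c1C(=O)c1ccc(Cl)cc1` has not yet been measured. It differs from compound 2 in one place: thiophen-3-yl in place of pyridin-3-yl on an aromatic carbon. For the measured compounds named here, whether such a ring change moves the read-out cannot be read from the three measured compounds, since no pair among them differs in only one place, and all three give the same low reading. The expectation is therefore that compound 4 remains at that low level, with a step of a number 1 percentage points higher from compound 2 to compound 4 (within the scatter) that amounts to nothing beyond the scatter. On that basis compound 4 is estimated at 2% in this assay, expected to fall between 0% and 12%.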

Compound 4, a percentage reported as inhibition, at one concentration (the size of the read-out at that concentration, not a potency): 2%
The estimate for compound 4 equals the measured number at the digits printed; the range from low to high includes it.
By their numbers in this assay, from the lowest: compounds 1, 2, 3 and 4 (each within the scatter of the next).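

In this assay, for the compounds shown here, putting thiophen-3-yl in place of pyridin-3-yl on the aromatic carbon next to the ring sulfur gives the only single-change step that can be read so far (a number 1 percentage points higher from compound 2 to compound 4 (within the scatter)). At this position, therefore, a five-membered aromatic ring with a sulfur and a six-membered aromatic ring with a nitrogen cannot be told apart by this read-out, and both compounds stay at a low reading, so this pair shows no sign that the choice between these two rings matters here. No measurement bears on why the two compounds read alike.

Compounds 1 and 3 carry bromine at this position but also differ from compounds 2 and 4 elsewhere, so the steps linking them to compounds 2 and 4 cannot be read. Still open, from the compounds shown here alone, is whether a group of a different kind on this carbon, such as an amine, a carboxylic acid or a longer chain, would lift the reading above this low level, and whether either ring would behave the same way on a version of the shared core that gives a higher reading.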